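Swapping the aryl group on the aminoketone core

The source may report more compounds than this note shows. Statements on the series, on what has been measured and on what is new or still open speak of the compounds shown alone.

Among the compounds with values here, compound 1 `Cc1ccc(NC(C(=O)CCc2ccncc2)c2ccccc2C(C)C)c(Cl)c1` is the only member of this small set with a numerical reading: in an assay on isolated protein for binding affinity to corticotropin-releasing factor receptor 1 (Homo sapiens) (a higher number here means a weaker inhibitor, a lower number a stronger inhibitor), compound 1 gives 3300 nM. Compound 2 `COc1cccc(C(Nc2ccc(C)cc2Cl)C(=O)CCc2ccncc2)c1` carries 3-methoxyphenyl in place of 2-isopropylphenyl. In this assay compound 2 reaches only the limit of > 10000 nM, which is a limit of the assay and not a number. Within the data shown here, that step, an at least 3.0-fold higher number from compound 1 to compound 2 (0.48 log units; beyond the scatter), is the one comparison that bears on the change now at hand, and it rests on (the limit of > 10000 nM in this assay, at which 1 of the 2 values shown sits).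

Compound 3 `Cc1ccc(C(Nc2ccc(C)cc2Cl)C(=O)CCc2ccncc2)cc1` differs from compound 1 in one place: 4-methylphenyl in place of 2-isopropylphenyl on a saturated chain carbon bound to a carbonyl carbon and a nitrogen on an aromatic ring. Among the measured compounds shown here, since the only measured exchange of this aryl group weakened binding in this assay, a weaker result is expected for compound 3 as well, estimated as a 3.6-fold higher number from compound 1 to compound 3 (0.56 log units; beyond the scatter). Compound 3 is therefore expected to give about 12000 nM in this assay, within a range from 4000 nM to 40000 nM.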

Compound 3, inhibition constant: > 10000 nM
Compound 3: no number, only a limit; the forecaster's own chance of this, stated with the estimate: 60%; the middle value does not contradict the limit.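

A second exchange at this position now points the same way in this assay: an at least 3.0-fold higher number from compound 1 to compound 3 (0.48 log units; beyond the scatter), a step that rests on a limit of the assay and not on a number. The entering 4-methylphenyl holds carbon only, so the weakening seen on leaving 2-isopropylphenyl is not tied to the methoxy group of compound 2. The step from compound 2 to compound 3 cannot be read, and the comparisons at this position share one constraint: the limit of > 10000 nM in this assay, at which 2 of the 3 values shown sit.

As far as these compounds go, how far compound 2 and compound 3 lie beyond the limit stays open. Also open, from the compounds shown here alone, is whether a 2-methylphenyl or a 4-isopropylphenyl group on this carbon would keep the reading of compound 1, which would show whether the isopropyl group or its place on the ring matters.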